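The source may hold more compounds than are shown below. What is called first, only, known or untested is meant among the compounds shown, and "the series" means these compounds.

Measured so far:
- compound 1, `O=C(/C=C/c1ccc([N+](=O)[O-])cc1)Nc1cc2c(Nc3ccc(F)c(Cl)c3)ncnc2cc1O[C@H]1CCOC1`, 12000 nM
- compound 2, `COc1cc(/C=C/C(=O)Nc2cc3c(Nc4ccc(F)c(Cl)c4)ncnc3cc2O[C@H]2CCOC2)cc(OC)c1O`, 27000 nM
- compound 3, `N#Cc1ccc(/C=C/C(=O)Nc2cc3c(Nc4ccc(F)c(Cl)c4)ncnc3cc2O[C@H]2CCOC2)cc1`, "not active" (no number reported)

These three compounds share one core and differ only in the aromatic ring at the end of the double-bonded chain. In a functional assay on A549 cells (Homo sapiens) for cytotoxicity, read by MTT assay, with a stated time of 72 h (a higher number here means a weaker inhibitor, a lower number a stronger inhibitor), compound 1 gives 12000 nM. Compound 2 gives the highest of the two numbers reported, 27000 nM, and compound 3 gives "not active" (no number reported), so no number stands for it. Within the data shown here, the one step between compounds that differ in a single place is a 2.3-fold higher number from compound 1 to compound 2 (0.35 log units; beyond the scatter), a modest worsening.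

Compound 4, `O=C(/C=C/c1ccccc1[N+](=O)[O-])Nc1cc2c(Nc3ccc(F)c(Cl)c3)ncnc2cc1O[C@H]1CCOC1`, has not been measured yet. It differs from compound 2 in one place: 2-nitrophenyl in place of 4-hydroxy-3,5-dimethoxyphenyl on a double-bonded chain carbon bound to a double-bonded chain carbon. The ring entering is a nitrophenyl, as in compound 1, though a 2-nitrophenyl rather than the 4-nitrophenyl of compound 1. The step from compound 1 to compound 2 therefore bears on it most directly, suggesting that undoing the change toward the dimethoxy ring would bring the number back toward that of compound 1. Nothing measured tells how a 2-nitrophenyl compares with a 4-nitrophenyl, so the range is kept wide.

Compound 4 is therefore expected to give about 15000 nM in this assay, between 5000 nM and 60000 nM, which amounts to an estimated step of a 1.8-fold lower number from compound 2 to compound 4 (0.26 log units; within the scatter).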

Compound 4, half-maximal inhibitory concentration: 8820 nM
For compound 4 the middle estimate is 1.7-fold (0.23 log units) above the measured one; low and high end bracket the measured number.
By their numbers in this assay, from the lowest: compounds 4 and 1 (each within the scatter of the next); then compound 2.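

In this assay, replacing 4-nitrophenyl with 2-nitrophenyl gives a 1.4-fold lower number from compound 1 to compound 4 (0.13 log units; within the scatter) and stays within the usual scatter, so this assay does not separate the two nitrophenyl rings at this position. Replacing 4-hydroxy-3,5-dimethoxyphenyl with 2-nitrophenyl gives a 3.1-fold lower number from compound 2 to compound 4 (0.49 log units; beyond the scatter) and lies beyond the scatter, so a second nitrophenyl compound now has a lower number than compound 2, though the change is modest. No measured evidence bears on why these rings behave as they do.

From the compounds shown here alone, it remains open whether a phenyl ring carrying an amine or a carboxylic acid instead of the nitro group would shift the number further. The compounds shown also leave open how a longer chain between the amide carbonyl and the ring would behave.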